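Heteroaryl amide swap on a shared core: expected edema inhibition

A few compounds are considered here, and "the series" means these few. Any claim that something is new, unique, unknown or untested is made for them only; others in the source may bear on it.

Compound 1 `O=C(Nc1ccc(Cl)cc1)c1c(O)c2cccnc2n(-c2ccccc2)c1=O` and compound 2 `Cc1ccccc1NC(=O)c1c(O)c2cccnc2n(-c2ccccc2)c1=O` share one core and differ only in the group on the amide-type nitrogen. In a functional assay on the whole organism for inhibition, with Rattus norvegicus as the target, read by paw edema, at a dose of 100 mg/kg by the oral route (on this read-out lower numbers stand for less inhibition and higher numbers for more inhibition at the one dose given (going by the name of the read-out)), compound 1 gives 11.6%, and compound 2 gives 11.7%. The step of a number 0.1 percentage points higher from compound 1 to compound 2 (within the scatter) shows nothing beyond the scatter, so compound 2 stands alongside compound 1, the two within the scatter of each other. Compound 3 `COc1ccc(NC(=O)c2c(O)c3cccnc3n(-c3ccccc3)c2=O)cn1` differs from compound 2 by 6-methoxypyridin-3-yl in place of 2-methylphenyl on an amide-type nitrogen. No measured step bears on a methoxy or a pyridine ring, and the one step shown was flat, so a step of a number 0.3 percentage points higher from compound 2 to compound 3 (within the scatter) is expected, none beyond the scatter. Compound 3 is estimated at 12%, between 2% and 26%.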

Compound 3, a percentage reported as inhibition, in the whole organism at one dose (the size of the read-out at that dose, not a potency): 13.1%
For compound 3 the middle estimate is 1.1 percentage points below the measured one; low and high end bracket the measured number.
By their numbers in this assay, from the lowest: compounds 1, 2 and 3 (each within the scatter of the next).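

With 6-methoxypyridin-3-yl on the amide-type nitrogen, this assay gives a number 1.4 percentage points higher from compound 2 to compound 3 (within the scatter) and a number 1.5 percentage points higher from compound 1 to compound 3 (within the scatter). At this position, then, an aromatic ring with a hetero atom and a methoxy group reads the same, within the scatter, as the two carbon-only aromatic rings. No supporting evidence bears on this result. On these data alone, whether an amine, a carboxylic acid or a longer chain on this nitrogen would move the number beyond the scatter remains open.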